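Aryl-piperazine series: cyclopropyl in place of propyl

The source may hold more compounds than are shown below. What is called first, only, known or untested is meant among the compounds shown, and "the series" means these compounds.

Measured so far:
compound 1, `CN(C)C(=O)c1cccnc1NCCCN1CCN(c2ccccc2C#N)CC1`, 10 nM in a functional assay on aorta for antagonist activity at Alpha-1D adrenergic receptor (Rattus norvegicus); on this read-out lower numbers stand for tighter binding and higher numbers for weaker binding
compound 2, `CN(C)C(=O)c1cccnc1NCCCN1CCN(c2ccccc2-c2ncco2)CC1`, 25.1 nM
compound 3, `CCCc1ccccc1N1CCN(CCCNc2ncccc2C(=O)N(C)C)CC1`, 31.6 nM

Compound 3 carries the highest number among the three shown. Its number and that of compound 2 lie within the scatter of each other, as a 1.3-fold higher number from compound 2 to compound 3 (0.10 log units; within the scatter) shows, whereas the step of a 3.2-fold higher number from compound 1 to compound 3 (0.50 log units; beyond the scatter) lies beyond it.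

Compound 4, `CN(C)C(=O)c1cccnc1NCCCN1CCN(c2ccccc2C2CC2)CC1`, has not yet been measured. It differs from compound 3 by cyclopropyl in place of propyl on an aromatic carbon. Within the data shown here, no measured pair covers this exchange directly. Among the measured compounds shown here, the steps that bear on it are the changes at the same aromatic carbon, a 2.5-fold higher number from compound 1 to compound 2 (0.40 log units; beyond the scatter) and a 3.2-fold higher number from compound 1 to compound 3 (0.50 log units; beyond the scatter), both modest, and a 1.3-fold higher number from compound 2 to compound 3 (0.10 log units; within the scatter), which stays within the scatter. Since the group entering keeps the same count of atoms as the group leaving, the expected step of a 1.3-fold lower number from compound 3 to compound 4 (0.10 log units; within the scatter) is small, with no clear direction beyond the scatter. Compound 4 is therefore estimated at 25 nM, within a range of 10 nM to 63 nM.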

Compound 4, dissociation constant: 63.1 nM
Compound 4: the middle estimate sits 2.5-fold (0.40 log units) below what was measured; the measured number lies above the stated range.
By their numbers in this assay, from the lowest: compound 1; then compounds 2, 3 and 4 (each within the scatter of the next, the first and the last beyond it).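

In this assay, cyclopropyl in place of propyl on this aromatic carbon gives a 2.0-fold higher number from compound 3 to compound 4 (0.30 log units; within the scatter), so exchanging the open chain for the three-membered ring, with the same count of heavy atoms, does not move the number beyond the scatter. Cyclopropyl does separate from 1,3-oxazol-2-yl, with a 2.5-fold higher number from compound 2 to compound 4 (0.40 log units; beyond the scatter), where propyl did not, and a 6.3-fold higher number from compound 1 to compound 4 (0.80 log units; beyond the scatter) is the widest step yet seen at this position. No measurement shown here accounts for these differences.

As far as these compounds go, all four compounds share one core and differ only at this carbon, so whether these steps carry over to another core remains open. From the compounds shown here alone, it is also open where a methoxy group, a primary amide or a longer chain such as butyl would fall relative to cyano at this position.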